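Hydroxycarbamoyl on the longer chain: expectation for compound 3

A few compounds are considered here, and "the series" means these few. Any claim that something is new, unique, unknown or untested is made for them only; others in the source may bear on it.

In a functional assay on CNE-2 cells (Homo sapiens) for inhibition, read by MTT assay, with a stated time of 72 h (on this read-out lower numbers stand for stronger inhibition and higher numbers for weaker inhibition), compound 1 (`Nc1nc2cc(-c3nn(CCC(=O)NO)c4ncnc(N)c34)ccc2o1`) gives > 150000 nM as a limit of the assay, not a number. In this assay, within the data shown here, compound 2 (`CNC(=O)CCCCCCCn1nc(-c2ccc3oc(N)nc3c2)c2c(N)ncnc21`) gives 2250 nM and so holds the only number so far.

Among the measured compounds shown here, the single measured step is large (an at least 66-fold lower number from compound 1 to compound 2 (1.82 log units; beyond the scatter)) and beyond the scatter. From the compounds shown here alone, it puts 5-(methylcarbamoyl)pentyl in place of hydroxycarbamoyl, so chain and end group change together, and the end group alone remains untested.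

Compound 3 (`Nc1nc2cc(-c3nn(CCCCCCC(=O)NO)c4ncnc(N)c34)ccc2o1`) differs from compound 2 by hydroxycarbamoyl in place of (methylcarbamoyl)methyl on a saturated chain carbon, six bonds along the chain from an aromatic nitrogen. It carries the end group of compound 1, but six bonds along the chain rather than two.

With the longer chain kept, a return to the limit of compound 1 is not expected. A moderate move to a lower number is expected instead, on thin evidence, and the estimated step (a 2.8-fold lower number from compound 2 to compound 3 (0.45 log units; beyond the scatter)) is correspondingly uncertain. For compound 3 the expected value in this assay is 800 nM with an estimated range from 100 nM to 4000 nM as its bounds.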

Compound 3, half-maximal inhibitory concentration: 4360 nM
For compound 3 the middle estimate is 5.5-fold (0.74 log units) below the measured one; measured number above the stated range.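

Among these compounds, with hydroxycarbamoyl kept as the end group, 4-(hydroxycarbamoyl)butyl in place of hydroxycarbamoyl gives an at least 34-fold lower number from compound 1 to compound 3 (1.53 log units; beyond the scatter) in this assay, so this is the first step that changes the chain alone, and the change is large. Hydroxycarbamoyl in place of (methylcarbamoyl)methyl, at the position six bonds along the chain from an aromatic nitrogen, gives a 1.9-fold higher number from compound 2 to compound 3 (0.29 log units; within the scatter), so on these longer chains the two end groups cannot be told apart in this assay, although this step changes chain length and end group together. Compound 1 remains a limit of the assay and not a number, so the large step from it fixes only a minimum size: the limit of > 150000 nM in this assay, at which 1 of the 3 values shown sits.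

From the compounds shown here alone, how the number moves at chain lengths between those of compound 1 and compound 3, or on a chain longer than that of compound 2, remains open. Also open is whether a carboxylic acid or a primary amide as the end group on the chain of compound 3 would separate from the two end groups shown in this assay.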